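Replacing a cyclopropyl-piperidine with a methylpiperidinylmethyl group

The source may hold more compounds than are shown below. What is called first, only, known or untested is meant among the compounds shown, and "the series" means these compounds.

Three compounds share a sulfonamide-ether-amide core and differ in the amine attached at the far end. Compound 1 `CCN(CC)CCN1CCN(C(=O)COCCN(C)S(=O)(=O)c2c(C)cc(OC)cc2C)CC1` carries a 2-(diethylamino)ethyl group and in an assay on HEK293 cells for displacement of a labelled ligand from B1 bradykinin receptor (Homo sapiens), read by scintillation counting (a lower number here means a stronger inhibitor, a higher number a weaker inhibitor), gives 10 nM. Compound 2 `COc1cc(C)c(S(=O)(=O)N(C)CCOCC(=O)N2CCC(C3CCN(C)CC3)CC2)c(C)c1` gives 0.7 nM in this assay. Compound 3 `COc1cc(C)c(S(=O)(=O)N(C)CCOCC(=O)N2CCN(C3CCN(C4CC4)CC3)CC2)c(C)c1` gives 0.8 nM in this assay, which places it close to compound 2, with a gap that lies within the scatter, and far from compound 1. Among the measured compounds shown here, the only step that changes the same position is a 13-fold lower number from compound 1 to compound 3 (1.10 log units; beyond the scatter), a large gain.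

Compound 4 `COc1cc(C)c(S(=O)(=O)N(C)CCOCC(=O)N2CCN(CC3CCN(C)CC3)CC2)c(C)c1` differs from compound 3 by (1-methylpiperidin-4-yl)methyl in place of 1-cyclopropylpiperidin-4-yl on an amine nitrogen in a ring. This keeps a piperidine ring but adds a one-carbon link and trades cyclopropyl for methyl. The gain seen in a 13-fold lower number from compound 1 to compound 3 (1.10 log units; beyond the scatter) suggests a ring at this position matters more than the group on its nitrogen, and compound 2 shows a methylpiperidine in a related setting gives 0.7 nM. A small loss, if any, is expected: a 2.5-fold higher number from compound 3 to compound 4 (0.40 log units; beyond the scatter). Compound 4 is therefore estimated at 2 nM, within a range of 0.6 nM to 8 nM.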

Compound 4, inhibition constant: 4.5 nM
Beside the measured number, compound 4's estimate is 2.3-fold (0.35 log units) below it; the range from low to high includes it.
By their numbers in this assay, from the lowest: compounds 2 and 3 (each within the scatter of the next); then compound 4; then compound 1.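

Keeping a piperidine ring on this amine nitrogen does not by itself hold the number: the change gives (a 5.6-fold higher number from compound 3 to compound 4 (0.75 log units; beyond the scatter)), a step beyond the scatter. Among the compounds shown here, the piperidine-bearing group in compound 4 still improves on the open-chain amine end of compound 1 (a 2.2-fold lower number from compound 1 to compound 4 (0.35 log units; beyond the scatter)), but this gain is smaller than the one seen with the group in compound 3 (a 13-fold lower number from compound 1 to compound 3 (1.10 log units; beyond the scatter)). No measured evidence here explains these differences.

The entering group differs in two ways at once, with methyl replacing cyclopropyl on the piperidine nitrogen and a carbon link added before the ring, so the compounds shown cannot say which of these accounts for the loss. A (1-cyclopropylpiperidin-4-yl)methyl group at this position would help separate the two changes.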